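Moving Two Chlorines on a Dichlorophenyl Amide

A few compounds are considered here, and "the series" means these few. Any claim that something is new, unique, unknown or untested is made for them only; others in the source may bear on it.

Of the compounds shown here, two from this series have been tested so far. Compound 1 `CCN(CC)CCNc1cc(C)c2cc(NC(=O)c3ccc(Cl)c(Cl)c3)ccc2n1` and compound 2 `CCN1CCN(c2cc(C)c3cc(NC(=O)c4cc(Cl)cc(Cl)c4)ccc3n2)CC1` were run in a functional assay on MCF7 cells (Homo sapiens) for antiproliferative activity, read by MTT assay, with a stated time of 72 h; on this read-out lower numbers stand for stronger inhibition and higher numbers for weaker inhibition. Compound 1 gives 1420 nM, while compound 2 gives 6090 nM, the higher of the two numbers and therefore the weaker inhibitor of the pair.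

The next step keeps everything in compound 2 except the dichlorophenyl ring and yields compound 3 `CCN1CCN(c2cc(C)c3cc(NC(=O)c4ccc(Cl)c(Cl)c4)ccc3n2)CC1`. The change is 3,4-dichlorophenyl in place of 3,5-dichlorophenyl on a carbonyl carbon. Compound 1 also bears the 3,4-dichlorophenyl group and shows the lower number, but it differs from compound 3 in a second place as well, so no clean comparison is available. Nothing else in the measured set isolates this rearrangement. The expectation is a modest fall in the number, with the step of a 1.9-fold lower number from compound 2 to compound 3 (0.28 log units; within the scatter) expected to be small to moderate. Compound 3 is therefore estimated at 3200 nM, with a likely range from 1200 nM to 8500 nM.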

Compound 3, half-maximal inhibitory concentration: 1380 nM
The estimate for compound 3 lay 2.3-fold (0.37 log units) above the measured number; the measured number falls inside the stated range.
By their numbers in this assay, from the lowest: compounds 3 and 1 (each within the scatter of the next); then compound 2.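

In this assay the exchange of 3,5-dichlorophenyl for 3,4-dichlorophenyl on a carbonyl carbon gives a 4.4-fold lower number from compound 2 to compound 3 (0.64 log units; beyond the scatter), so with the same atoms joined differently, the placing of the chlorines alone separates these two compounds. The second comparison, 4-ethylpiperazin-1-yl in place of (2-(diethylamino)ethyl)amino on an aromatic carbon, gives a 1.0-fold lower number from compound 1 to compound 3 (0.01 log units; within the scatter), so with the 3,4-dichlorophenyl amide in place this exchange leaves no difference that can be read. The data shown offer no independent measurement that explains either result.

Still open, from the compounds shown here alone, is how a 4-chlorophenyl or 3,4-difluorophenyl group would compare on the same carbonyl carbon. The compounds shown also leave open whether the chlorine step would carry over to a compound with the (2-(diethylamino)ethyl)amino group.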